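Small chain extension on a weakly cytotoxic triazine

A few compounds are considered here, and "the series" means these few. Any claim that something is new, unique, unknown or untested is made for them only; others in the source may bear on it.

Measured compounds:
- Compound 1, `CNc1nc(Nc2ccc(C#N)cc2)nc(Oc2cccc3ccccc23)n1`: 30300 nM
- Compound 2, `CCCNc1nc(Nc2ccc(C#N)cc2)nc(Oc2cccc3ccccc23)n1`: 29500 nM
- Compound 3, `CNc1nc(Nc2ccc(C#N)cc2)nc(Oc2ccc(Cl)c3ccccc23)n1`: 197000 nM

All three share one core and were tested in an ADME assay on MT4 cells (Homo sapiens) for cytotoxicity, read by MTT assay, with a stated time of 4 days; on this read-out higher numbers stand for lower toxicity in this test and lower numbers for higher toxicity in this test. Compound 3 gives the highest number of the three: the step of a 6.5-fold higher number from compound 1 to compound 3 (0.81 log units; beyond the scatter), which came with a chloro in place of hydrogen on an aromatic carbon, was beyond the scatter, and compound 2 sits even a little further from compound 3, though compound 1 and compound 2 are within the scatter of each other.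

Compound 4, `CCNc1nc(Nc2ccc(C#N)cc2)nc(Oc2ccc(Cl)c3ccccc23)n1`, has not yet been measured. It differs from compound 3 by methyl in place of hydrogen on a saturated chain carbon bound to a nitrogen on an aromatic ring. Within the data shown here, only one measured step touches that same place on the molecule: a 1.0-fold lower number from compound 1 to compound 2 (0.01 log units; within the scatter), where the chain grew by more than one carbon and the number barely moved. On that basis, the smaller growth from methylamino to ethylamino is expected to leave the read-out essentially where it is, with no step beyond the scatter: an estimated 1.0-fold lower number from compound 3 to compound 4 (0.02 log units; within the scatter).

Compound 4 is therefore estimated at 190000 nM, within a range from 80000 nM to 450000 nM.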

Compound 4, half-maximal cytotoxic concentration: 208000 nM
Compound 4: the middle estimate sits 1.1-fold (0.04 log units) below what was measured, within the range that was stated.
By their numbers in this assay, from the lowest: compounds 2 and 1 (each within the scatter of the next); then compounds 3 and 4 (each within the scatter of the next).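

With the chloro group present, the move from methylamino to ethylamino gives a 1.1-fold higher number from compound 3 to compound 4 (0.02 log units; within the scatter) in this assay, so this small addition of one methyl leaves the read-out unchanged. The earlier step at this position, a 1.0-fold lower number from compound 1 to compound 2 (0.01 log units; within the scatter), came from compounds without the chloro group; the chain position has now shown no step beyond the scatter both with and without that group. No measurement available here explains why the read-out stays flat at this position.

The compounds shown carry only short, plain chains at this position, so a longer chain such as butyl, or a chain ending in an amine or a carboxylic acid, could still behave differently. On these data alone, whether fluoro or methoxy in place of the chloro group would also raise the number remains open.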